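The compounds below may be only part of what the source reports. "The series", "measured", "known", "first", "only" and "open" are said of these compounds alone.

Working notes on the series. Compound 1 `CC1=CC[C@H](C(C)(C)NC(=S)N/N=C/c2ccccc2)CC1` carries an unsubstituted benzylidene arm; compound 2 `CC1=CC[C@H](C(C)(C)NC(=S)N/N=C/c2ccccc2Cl)CC1` adds a chloro to it. In an ADME assay on Vero cells (Chlorocebus sabaeus) for inhibition, read by sulforhodamine B assay, with a stated time of 48 h (a higher number here means a weaker inhibitor of growth, a lower number a stronger inhibitor of growth), compound 1 gives only a limit, > 100000 nM. In this assay compound 2 likewise gives only a limit, > 100000 nM. Compound 2 thus stands at the limit of this assay, with no number of its own. The step that the two limits leave unreadable from compound 1 to compound 2 cannot be sized because both of its ends sit at the limit (the limit of > 100000 nM in this assay, at which 2 of the 2 values shown sit). Compound 3 `CC1=CC[C@H](C(C)(C)NC(=S)N/N=C/c2ccccc2[N+](=O)[O-])CC1` differs from compound 2 by nitro in place of chloro on an aromatic carbon. Going by the values given here, only the step that the two limits leave unreadable from compound 1 to compound 2 bears on this change, and it gives no readable size, so no direction is taken from it. Compound 3 is expected to give another limit in this assay, estimated at 150000 nM with a range of 50000 nM to 500000 nM. The estimated step that the limit leaves unreadable from compound 2 to compound 3 is expected to be no change beyond the scatter.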

Compound 3, concentration for total growth inhibition: > 100000 nM
Compound 3: a limit, no number; the forecaster's own chance of this, stated with the estimate: 80%; the middle value is on the limit's open side.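

In this assay compound 3 gives > 100000 nM, a limit and not a number. The steps to compound 3 from compound 1 and compound 2 cannot be read: the limit of > 100000 nM in this assay, at which 3 of the 3 values shown sit. The compounds shown leave open whether chloro or nitro on the benzylidene arm changes growth inhibition at all.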